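The compounds below may be only part of what the source reports. "The series", "measured", "known", "first", "only" and "open" are said of these compounds alone.

Working notes on the series. In a functional assay on SK-BR-3 cells (Homo sapiens) for cytotoxicity, read by MTT assay, with a stated time of 72 h (on this read-out higher numbers stand for weaker inhibition and lower numbers for stronger inhibition), the shared core carries an amide, an amino substituent and a bromine. Compound 1 `N[C@H]1CC[C@H](Nc2c(C(=O)NCc3ccccn3)nc(Br)c3cccnc23)CC1` has a (pyridin-2-yl)methyl amide and a trans-diaminocyclohexane on the amino position; in this assay compound 1 gives "not determined" (no result reported), so no number places it. Compound 2 `NCCCNc1c(C(=O)NCc2ccc(F)cc2)ncc2cccnc12` returns only a limit, > 10000 nM, in this assay. Compound 3 `N[C@H]1CC[C@H](NC(=O)c2nc(Br)c3cccnc3c2NCc2ccc(F)cc2)CC1`, with the 4-fluorobenzyl group on the amino position and the cyclohexanediamine on the amide, gives 2800 nM in this assay. Compound 4 `N[C@H]1CC[C@H](Nc2c(C(=O)NCc3ccc(F)cc3)nc(Br)c3cccnc23)CC1` differs from compound 1 by 4-fluorophenyl in place of pyridin-2-yl on a saturated chain carbon bound to an amide-type nitrogen. For the measured compounds named here, no measured step covers this change; with compound 1 unplaced, the expectation rests on compound 3 at 2800 nM. Compound 4 is estimated at 3000 nM, expected between 800 nM and 10000 nM.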

Compound 4, half-maximal inhibitory concentration: 2000 nM
Beside the measured number, compound 4's estimate is 1.5-fold (0.18 log units) above it; low and high end bracket the measured number.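

In this assay, for the compounds shown here, compound 1 carries no result, so no step from it to compound 4 can be read. From the compounds shown here alone, what swapping pyridin-2-yl for 4-fluorophenyl does to the value stays open. Nothing shown here bears on compound 4's result.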